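Indole series: piperidine amine variation and 5-HT1D binding

The source may report more compounds than this note shows. Statements on the series, on what has been measured and on what is new or still open speak of the compounds shown alone.

Three members of the series carry numbers in an assay on CHO cells for displacement of a labelled ligand from 5-hydroxytryptamine receptor 1D (Homo sapiens); on this read-out lower numbers stand for stronger inhibition and higher numbers for weaker inhibition. Compound 1 `CC(C)=CCCN(C)C1CCN(CCCc2c[nH]c3ccc(-n4cnnc4)cc23)CC1` gives 2.6 nM, compound 2 `OC[C@H](NC1CCN(CCCc2c[nH]c3ccc(-n4ccnc4)cc23)CC1)c1ccccc1` gives 0.7 nM and compound 3 `CC(=O)Nc1ccc([C@@H](C)NCC2CCN(CCCc3c[nH]c4ccc(-n5cnnc5)cc34)CC2)cc1` gives 1.5 nM. Compound 1 has the highest of the three numbers; the gap to compound 3 lies within the scatter, the gap to compound 2 lies beyond it, so compound 2 binds more strongly than compound 1 while compounds 1 and 3 cannot be ordered.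

Compound 4 `CN(Cc1ccccc1)CC1CCN(CCCc2c[nH]c3ccc(-n4cnnc4)cc23)CC1` is not yet measured in this assay. It differs from compound 1 in one place: (benzyl(methyl)amino)methyl in place of methyl(4-methylpent-3-en-1-yl)amino on a saturated ring carbon. For the measured compounds named here, the three measured compounds give no pair that differs in one place, so no measured step guides this change. Compound 3, which also carries an amine-bearing methyl on the saturated ring carbon, gives 1.5 nM, and compound 4 is expected to land in the same region, with a step of a 1.7-fold lower number from compound 1 to compound 4 (0.24 log units; within the scatter) that is expected to stay close to the scatter. The estimate for compound 4 is 1.5 nM, with a range from 0.5 nM to 5 nM.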

Compound 4, half-maximal inhibitory concentration: 0.9 nM
Estimate against measurement, compound 4: 1.7-fold (0.22 log units) above; the range from low to high includes it.
By their numbers in this assay, from the lowest: compounds 2, 4, 3 and 1 (each within the scatter of the next, the first and the last beyond it).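

In this assay the series now has its first step that differs in one place, a 2.9-fold lower number from compound 1 to compound 4 (0.46 log units; beyond the scatter), so the group on this saturated ring carbon can shift binding beyond the scatter. The open chain with its double bond can give way to a group with a six-membered aromatic ring of carbon only and a methyl link before the amine nitrogen, with no loss of binding. Nothing at hand explains the size of this step.

The step changes these features together, so the compounds shown do not assign it to the aromatic ring, the methyl link or the loss of the double bond. Open, on these data alone, is how a benzyl(methyl)amino group placed directly on the ring carbon would compare, and whether a pyridylmethyl group could stand in for the benzyl.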